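This account rests on a few compounds, and the source may have more. Where it says the series, first, only, none or still open, it means among the compounds named here.

Of the compounds shown here, three sharing one core have been measured in a functional assay on RPMI 8402 cells (Homo sapiens) for cytotoxicity; a lower number here means a stronger inhibitor, a higher number a weaker inhibitor. Compound 1 `N#Cc1ccc2[nH]c(-c3ccc4[nH]c(-c5ccc6[nH]cnc6c5)nc4c3)nc2c1`, which carries a cyano group, gives > 25000 nM, and this is a limit of the assay and not a number. Compound 2 `c1cncc(-c2ccc3[nH]c(-c4ccc5[nH]c(-c6ccc7[nH]cnc7c6)nc5c4)nc3c2)c1`, with pyridin-3-yl in that place, gives 2500 nM. Compound 3 `c1cc(-c2ccc3[nH]c(-c4ccc5[nH]c(-c6ccc7[nH]cnc7c6)nc5c4)nc3c2)ccn1`, with pyridin-4-yl there, gives 2500 nM. Compound 3 therefore stands level with compound 2, the nearest value, with no change at the digits printed from compound 2 to compound 3 (within the scatter).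

Compound 4 `c1ccc2[nH]c(-c3ccc4[nH]c(-c5ccc6[nH]cnc6c5)nc4c3)nc2c1` has no such ring: hydrogen in place of pyridin-4-yl on an aromatic carbon. Going by the values given here, no measured step makes this exact change, so the evidence is indirect. Replacing cyano gave an at least 10-fold lower number from compound 1 to compound 2 (1.00 log units; beyond the scatter) and also an at least 10-fold lower number from compound 1 to compound 3 (1.00 log units; beyond the scatter), so the group at this carbon can matter in this assay. Compound 4 carries neither the cyano group of compound 1 nor a pyridine ring, which leaves its place between these results open. A move toward a higher number, a weaker result, is expected, though a modest one and with wide uncertainty. The expected step is a 2.4-fold higher number from compound 3 to compound 4 (0.38 log units; beyond the scatter). For compound 4 the estimated value is 6000 nM, with an expected range of 1200 nM to 25000 nM.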

Compound 4, half-maximal inhibitory concentration: 28000 nM
Beside the measured number, compound 4's estimate is 4.7-fold (0.67 log units) below it; measured number outside the range, above it.
By their numbers in this assay, from the lowest: compounds 2 and 3 (each within the scatter of the next); then compound 4.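

In this assay, taking the ring away altogether gives an 11-fold higher number from compound 3 to compound 4 (1.05 log units; beyond the scatter) and an 11-fold higher number from compound 2 to compound 4 (1.05 log units; beyond the scatter), so the two pyridine rings on this aromatic carbon, alike in their values, stand apart from plain hydrogen by a large step beyond the scatter. The earlier compounds shown here had compared the pyridine rings only with cyano and with each other, whereas compound 4 now gives a measured reference for the carbon with no group on it, and the pyridine ring is what separates compound 2 and compound 3 from that reference. Compound 1 remains a limit of the assay and not a number, so its step to compound 4 cannot be read, and cyano and hydrogen cannot be ranked against each other: the limit of > 25000 nM in this assay, at which 1 of the 4 values shown sits.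

What a phenyl ring would give on this carbon stays open, so the compounds shown cannot tell whether the ring itself or its nitrogen matters. Also open, from the compounds shown here alone, is how an amine or a carboxylic acid at this place would compare with the pyridine rings of compound 2 and compound 3.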